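A few compounds are considered here, and "the series" means these few. Any claim that something is new, unique, unknown or untested is made for them only; others in the source may bear on it.

Working notes on a small set of selenium-bearing aryl carbamates read in an ADME assay on BEAS-2B cells (Homo sapiens) for cytotoxicity, read by MTT assay, with a stated time of 72 h; a lower number here means a stronger inhibitor of growth, a higher number a weaker inhibitor of growth. Among the compounds with values here, compound 1 `CCCCOC(=O)Nc1ccc([Se]C#N)cc1` gives 12200 nM in this assay, the lowest of the three numbers known so far and thus the strongest inhibitor of growth of the set. Compound 3 `N#C[Se]c1ccc(NC(=O)Oc2ccc(Cl)cc2)cc1` gives 38000 nM in this assay, and compound 2 `CCOC(=O)Nc1ccc([Se][Se]c2ccc(NC(=O)OCC)cc2)cc1`, the diselenide, gives 44000 nM; both gaps to compound 1 fall beyond the scatter. Within the data shown here, no two of these three differ in only one place, so no single counted step can be drawn among them.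

Compound 4 `CCOC(=O)Nc1ccc([Se]C#N)cc1` is yet to be measured in this assay. Against compound 1 it shows (hydrogen in place of ethyl on a saturated chain carbon, two bonds along the chain from an oxygen next to a carbonyl group), which shortens the carbamate ester chain and leaves the selenocyanate and the shared core untouched. The known numbers give no direct reading on this kind of change; the step from compound 1 to compound 4 is therefore expected to lie within the scatter, at most a modest drift toward a higher number, a 1.5-fold higher number from compound 1 to compound 4 (0.17 log units; within the scatter). For compound 4 the estimate in this assay is 18000 nM, with a range from 8000 nM to 40000 nM.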

Compound 4, concentration for total growth inhibition: 46900 nM
Compound 4: middle estimate off by 2.6-fold (0.42 log units), on the low side, and the stated range ends below it.
By their numbers in this assay, from the lowest: compound 1; then compounds 3, 2 and 4 (each within the scatter of the next).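

In this assay, within the data shown here, the carbamate ester chain is the first place where a single change can be read: butoxy to ethoxy, with the selenocyanate and the shared core untouched, gives a 3.8-fold higher number from compound 1 to compound 4 (0.58 log units; beyond the scatter) and so lies beyond the scatter. The ester chain is therefore not a silent place in this read-out, as the loss of 2 carbon atoms from its outer end moves the number toward weaker inhibition of growth. Nothing measured here bears on why the shorter chain reads this way.

A single step cannot show whether the number follows chain length steadily, or how a longer chain such as hexyl or a branched chain such as isopropyl would read. As far as these compounds go, whether the same shortening carries the same step among the diselenides also remains open.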